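This account rests on a few compounds, and the source may have more. Where it says the series, first, only, none or still open, it means among the compounds named here.

Working notes on the series. Two compounds sharing a common core have readings in a physicochemical assay for lipophilicity; on this read-out higher numbers stand for higher lipophilicity and lower numbers for lower lipophilicity. Compound 1 `COCCNC(=O)C[C@H](NC(=O)c1ccc(C#Cc2ccccc2)cc1)C(=O)NO` gives 2 and stands lowest of the two numbers. Compound 2 `O=C(NC1(C(=O)NO)CCNCC1)c1ccc(C#Cc2ccccc2)cc1` gives 3, a reading higher than compound 1 and beyond the scatter. Compound 3 `CS(=O)(=O)C[C@H](NC(=O)c1ccc(C#Cc2ccccc2)cc1)C(=O)NO` is not yet measured; it differs from compound 1 in one place, (methylsulfonyl in place of (2-methoxyethyl)carbamoyl on a saturated chain carbon, two bonds along the chain from an amide-type nitrogen and a carbonyl carbon). For the measured compounds named here, no measured pair shows this change, so its size rests on expectation. For compound 3 the expected step in this assay is a number 0.30 log units lower from compound 1 to compound 3 (within the scatter), a small shift downward that may lie within the scatter. Compound 3 is estimated at 1.7, with a range from 1 to 2.4.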

Compound 3, distribution coefficient: 2
Beside the measured number, compound 3's estimate is 0.30 log units below it; low and high end bracket the measured number.
By their numbers in this assay, from the lowest: compounds 1 and 3 (each within the scatter of the next); then compound 2.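

In this assay, the step for methylsulfonyl in place of (2-methoxyethyl)carbamoyl on this saturated chain carbon reads no change at the digits printed from compound 1 to compound 3 (within the scatter). For the compounds shown here, this is the first measured step at this position, and it shows that the group of 7 heavy atoms with 1 hydrogen-bond donor and the group of 4 heavy atoms with 0 donors cannot be told apart on this read-out. Nothing available accounts for this result.

On these data alone, whether an amine, a carboxylic acid or a longer chain ending in methylsulfonyl at this position would also stay within the scatter of compound 1 remains open. Going by these compounds alone, compound 2 differs from compound 1 in more than one place, so it gives no step to settle this.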